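The source may hold more compounds than are shown below. What is called first, only, known or untested is meant among the compounds shown, and "the series" means these compounds.

Measured compounds in an assay on isolated protein for inhibition of cathepsin S (Homo sapiens), read by fluorescence; a higher number here means a weaker inhibitor, a lower number a stronger inhibitor:
compound 1, `CC(C=O)NC(=O)c1cccc(C(F)(F)F)c1Cl`, gives 110 nM
compound 2, `CC(NC(=O)c1cccc(C(F)(F)F)c1Cl)C(=O)C(=O)Nc1cc[nH]n1`, gives 14.1 nM
compound 3, `CCCCC(NC(=O)c1ccc(OCc2ccccn2)c(C(F)(F)F)c1Cl)C(=O)C(=O)Nc1ccn(C)n1`, gives 1.9 nM

Compound 1 stands highest of the three numbers in this assay. Within the data shown here, its nearest neighbour is compound 2, reached by the only single-point step recorded in the set, a 7.8-fold lower number from compound 1 to compound 2 (0.89 log units; beyond the scatter), which places a (1H-pyrazol-3-yl)carbamoyl where compound 1 carries a hydrogen on the carbonyl carbon. Compound 3 differs from compound 2 in more than one place, so its two values can only be read side by side: compound 3 sits lowest of the three.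

Compound 4, `CCC(C=O)NC(=O)c1cccc(C(F)(F)F)c1Cl`, is the next compound to be measured. Against compound 1 the change is methyl in place of hydrogen on a saturated chain carbon, two bonds along the chain from an amide-type nitrogen and a carbonyl carbon, which read one bond further out is methyl to ethyl, or 1-formylethyl to 1-formylpropyl. Among the measured compounds shown here, no recorded step touches this saturated chain carbon: the step from compound 1 to compound 2 acts at the carbonyl end, and compound 3 carries a longer chain there only together with other changes. The expectation is therefore a small step downward or none beyond the scatter, a 1.6-fold lower number from compound 1 to compound 4 (0.20 log units; within the scatter). Compound 4 is estimated at 70 nM in this assay, with a range from 25 nM to 200 nM.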

Compound 4, half-maximal inhibitory concentration: 31 nM
Compound 4: the middle estimate sits 2.3-fold (0.35 log units) above what was measured, and the stated range covers the measured number.
By their numbers in this assay, from the lowest: compound 3; then compound 2; then compound 4; then compound 1.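

In this assay, the saturated chain carbon two bonds along the chain from an amide-type nitrogen and a carbonyl carbon responds to a single added methyl: that change gives a 3.5-fold lower number from compound 1 to compound 4 (0.55 log units; beyond the scatter) and lies beyond the scatter. Among these compounds, the only earlier single-place step, a 7.8-fold lower number from compound 1 to compound 2 (0.89 log units; beyond the scatter), acts at the carbonyl end, whereas this step reads the chain on its own, with the formyl end unchanged, and shows that the methyl to ethyl change alone moves the number. No supporting measurement is available to explain this step.

Among the compounds shown here, what remains open is whether the downward step continues, stops or reverses when a propyl or an isopropyl group stands in place of the ethyl on the same carbon, since the ethyl compound gives the only single-place reading of this chain. It is also open whether the ethyl in place of the methyl gives a step of similar size when the core carries the (1H-pyrazol-3-yl)carbamoyl of compound 2, as no pair among the compounds shown tests the two changes together.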